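Swapping an amide for a sulfonamide on a shared core

This account rests on a few compounds, and the source may have more. Where it says the series, first, only, none or still open, it means among the compounds named here.

Compounds measured so far:
- Compound 1, `CN(C(=O)c1ccc(Cl)cc1)c1ccc2[nH]c(-c3n[nH]c4ccccc34)cc2n1`, gives 3000 nM in a functional assay on HCT-116 cells (Homo sapiens) for antiproliferative activity, read by MTT assay, with a stated time of 72 h; on this read-out higher numbers stand for weaker inhibition and lower numbers for stronger inhibition.
- Compound 2, `CN(C(=O)c1ccc(Br)cc1)c1ccc2[nH]c(-c3n[nH]c4ccccc34)cc2n1`, gives 6110 nM in this assay.
- Compound 3, `CN(C(=O)c1ccc([N+](=O)[O-])cc1)c1ccc2[nH]c(-c3n[nH]c4ccccc34)cc2n1`, gives 19900 nM in this assay.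

Among these three, compound 2 holds the middle place: the step of a 2.0-fold higher number from compound 1 to compound 2 (0.31 log units; beyond the scatter) sets it apart from compound 1, and the step of a 3.3-fold higher number from compound 2 to compound 3 (0.51 log units; beyond the scatter) sets it apart from compound 3. The largest gap is the step of a 6.6-fold higher number from compound 1 to compound 3 (0.82 log units; beyond the scatter).

Compound 4, `CN(c1ccc2[nH]c(-c3n[nH]c4ccccc34)cc2n1)S(=O)(=O)c1ccc(Cl)cc1`, has not been measured. It differs from compound 2 in one place: (4-chlorophenyl)sulfonyl in place of (4-bromophenyl)carbonyl on a nitrogen on an aromatic ring. This change bundles two things. The halogen goes from bromine back to chlorine, which is the reverse of the measured step from compound 1 to compound 2, so on that part alone a modest move toward a lower number would be expected. Among the compounds with values here, the carbonyl-to-sulfonyl exchange, however, has no counterpart among the measured compounds, and nothing here tells how large its effect is or in which direction it points. The expectation for compound 4 is therefore anchored near compound 1 but with a wide spread, expected as a 1.7-fold lower number from compound 2 to compound 4 (0.24 log units; within the scatter). Compound 4 is estimated at 3500 nM, with a range from 800 nM to 15000 nM.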

Compound 4, half-maximal inhibitory concentration: 5980 nM
Compound 4: middle estimate off by 1.7-fold (0.23 log units), on the low side; the measured number falls inside the stated range.
By their numbers in this assay, from the lowest: compounds 1, 4 and 2 (each within the scatter of the next, the first and the last beyond it); then compound 3.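

Within the data shown here, the step of a 2.0-fold higher number from compound 1 to compound 4 (0.30 log units; within the scatter) keeps the chlorine and exchanges only the carbonyl for a sulfonyl, so it isolates a change that the earlier compounds could not separate, and in this assay that exchange on the nitrogen gives no difference that can be told from the scatter. The step of a 1.0-fold lower number from compound 2 to compound 4 (0.01 log units; within the scatter) alters the halogen and the linking group together and also stays within the scatter, so the sulfonyl can stand at this position with the number remaining in the range of the two halogen-bearing amides. No measurement on hand offers an explanation for this result.

The compounds shown leave open whether the sulfonyl and the carbonyl would still read alike with a bromine or a nitro group on the ring, as only the chlorine is seen in both forms. They also do not tell what an amine or a carboxylic acid would do in place of that halogen, or how a simple methyl on the sulfonyl would compare with the 4-chlorophenyl group.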